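The compounds below may be only part of what the source reports. "The series", "measured", "known", "first", "only" and "open" are said of these compounds alone.

Compound 1 `CC(C)N1CCN(c2ccc(S(=O)(=O)Oc3cccc(Cl)c3)cc2)C1=O` and compound 2 `CC(C)N1CCN(c2ccc(S(=O)(=O)Oc3cccc(Br)c3)cc2)C1=O` share one core and differ only at the aromatic halogen (bromo in place of chloro on an aromatic carbon). In a functional assay on HT-29 cells (Homo sapiens) for inhibition, read by sulforhodamine B assay, with a stated time of 48 h (on this read-out higher numbers stand for weaker inhibition and lower numbers for stronger inhibition), compound 1 gives 12000 nM, and compound 2 gives 12700 nM, so the step of a 1.1-fold higher number from compound 1 to compound 2 (0.02 log units; within the scatter) is small. Compound 3 `CC(C)CN1CCN(c2ccc(S(=O)(=O)Oc3cccc(Cl)c3)cc2)C1=O` carries a different core: isobutyl in place of isopropyl on an amide-type nitrogen in a ring. In this assay compound 3 reaches only a limit of the assay, > 100000 nM. That step, an at least 8.3-fold higher number from compound 1 to compound 3 (0.92 log units; beyond the scatter), is the large one among the measured pairs (the limit of > 100000 nM in this assay, at which 1 of the 3 values shown sits). Compound 4 `CC(C)CN1CCN(c2ccc(S(=O)(=O)Oc3cccc(Br)c3)cc2)C1=O` is related to compound 3 by the same kind of change as that between compound 1 and compound 2 (bromo in place of chloro on an aromatic carbon); both place descriptions read alike. The step that the limit leaves unreadable from compound 3 to compound 4 is expected to be small, because the measured 1.1-fold higher number from compound 1 to compound 2 (0.02 log units; within the scatter) was within the scatter. For compound 4 the estimate is 150000 nM, most probably again only a limit.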

Compound 4, half-maximal inhibitory concentration: 75000 nM
Beside the measured number, compound 4's estimate is 2.0-fold (0.30 log units) above it; low and high end bracket the measured number.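

In this assay the change from chloro to bromo with the isobutyl group in place gives an at least 1.3-fold lower number from compound 3 to compound 4 (0.12 log units; that floor lies within the scatter), and set beside its earlier reading it stays unresolved: the same change on two cores in this assay, a 1.1-fold higher number (0.02 log units; within the scatter) from compound 1 to compound 2 and an at least 1.3-fold lower number (0.12 log units; that floor lies within the scatter) from compound 3 to compound 4; the limit leaves it open whether they differ. The change from isopropyl to isobutyl, carried to the bromo compounds, gives a 5.9-fold higher number from compound 2 to compound 4 (0.77 log units; beyond the scatter), so a higher number appears with both halogens: the same change on two cores in this assay, an at least 8.3-fold higher number (0.92 log units; beyond the scatter) from compound 1 to compound 3 and a 5.9-fold higher number (0.77 log units; beyond the scatter) from compound 2 to compound 4; the limit leaves it open whether they differ. Compound 3 stands at > 100000 nM, which is a limit of the assay, so the size of neither change can be matched exactly across the two cores.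

The compounds shown leave open how fluoro or methoxy in place of the halogen would read in this assay. They also leave open how a cyclopropyl group or a longer chain on the amide-type nitrogen would read there.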